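The source may report more compounds than this note shows. Statements on the series, on what has been measured and on what is new or still open speak of the compounds shown alone.

Compound 1 `COc1cc2c(Oc3ccc(NC(=O)c4cc(-c5ccc(F)cc5)ccn4)cc3F)ccnc2cc1OCCCN1CCCCC1` gives 1240 nM in a functional assay on MKN-45 cells (Homo sapiens) for cytotoxicity, read by MTT assay, with a stated time of 72 h; a higher number here means a weaker inhibitor, a lower number a stronger inhibitor.
Compound 2 `COc1cc2c(Oc3ccc(NC(=O)c4cc(-c5ccc(F)cc5)ccn4)cc3F)ccnc2cc1OCCCN1CCN(C)CC1` gives 510 nM in this assay.
Compound 3 `COc1cc2c(Oc3ccc(NC(=O)c4cc(-c5ccc(F)cc5)ccn4)cc3F)ccnc2cc1OCCCN1CCCC1` gives 350 nM in this assay.

Among these three, compound 1 stands at the highest number. The step of a 2.4-fold lower number from compound 1 to compound 2 (0.39 log units; beyond the scatter) and the step of a 3.5-fold lower number from compound 1 to compound 3 (0.55 log units; beyond the scatter) both run downward and both lie beyond the scatter, while the step of a 1.5-fold lower number from compound 2 to compound 3 (0.16 log units; within the scatter) stays within it. Each of those three steps alters only the saturated amine that sits three bonds along the chain from an oxygen on an aromatic ring; the 4-fluorophenyl on the pyridine amide is the same in all of them.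

Compound 4 `COc1cc2c(Oc3ccc(NC(=O)c4cc(-c5ccccc5)ccn4)cc3F)ccnc2cc1OCCCN1CCCCC1` is compound 1 with one change: hydrogen in place of fluoro on an aromatic carbon. Among the compounds with values here, no measured step touches this part of the molecule, so the measured series offers no direct guide to its size or direction. In the absence of any such step, the expectation is that the change produces no step beyond the scatter in this assay. The estimate for compound 4 in this assay is therefore 1240 nM, with a range from 450 nM to 3400 nM. This estimate corresponds to an expected step of no change at the digits printed from compound 1 to compound 4 (within the scatter).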

Compound 4, half-maximal inhibitory concentration: 270 nM
Estimate against measurement, compound 4: 4.6-fold (0.66 log units) above, and the stated range ends above it.
By their numbers in this assay, from the lowest: compounds 4, 3 and 2 (each within the scatter of the next); then compound 1.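

Taking the fluoro off the 4-fluorophenyl group gives a 4.6-fold lower number from compound 1 to compound 4 (0.66 log units; beyond the scatter) in this assay. This is the first change shown away from the saturated amine, and it shows that this aromatic carbon, para to a large group, is not a silent place in the molecule: with the piperidin-1-yl chain and the rest of compound 1 held fixed, hydrogen in place of a single fluoro moves the number beyond the scatter, and the fluoro-bearing compound is the one with the higher number. Nothing measured here accounts for this step, so the result stands as an observation on this one pair of compounds.

The compounds shown leave open whether phenyl in place of 4-fluorophenyl would lower the number in the same way when the chain ends in pyrrolidin-1-yl or 4-methylpiperazin-1-yl rather than piperidin-1-yl. They also leave open how other groups on this carbon, such as chloro, methyl, methoxy or a nitrile, would stand against hydrogen and fluoro, and so whether the step reflects the loss of fluoro alone or a wider trend at this place.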